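This account rests on a few compounds, and the source may have more. Where it says the series, first, only, none or still open, it means among the compounds named here.

Measured compounds:
- Compound 1 `CN(C)C(=O)c1cc2cnc(Nc3ccc(NC(=O)C4(C(=O)Nc5ccc(Br)cc5)CC4)cc3)nc2n1C1CCCC1`: -6.6%
- Compound 2 `Cc1cccc(NC(=O)C2(C(=O)Nc3ccc(Nc4ncc5cc(C(=O)N(C)C)n(C6CCCC6)c5n4)cc3)CC2)c1`: 35.2%
- Compound 3 `COc1cccc(NC(=O)C2(C(=O)Nc3ccc(Nc4ncc5cc(C(=O)N(C)C)n(C6CCCC6)c5n4)cc3)CC2)c1`: 77.2%

In a functional assay on A549 cells (Homo sapiens) for inhibition, read by CCK-8 assay, with a stated time of 72 h, tested at 1 uM (a lower number here means less inhibition of growth, a higher number more inhibition of growth at the concentration tested), compound 1 gives -6.6%, the lowest of the three numbers. Compound 2 lies a number 41.8 percentage points higher from compound 1 to compound 2 (beyond the scatter), and compound 3 lies a number 83.8 percentage points higher from compound 1 to compound 3 (beyond the scatter), both large steps and both beyond the scatter. Compound 4 `CN(C)C(=O)c1cc2cnc(Nc3ccc(NC(=O)C4(C(=O)Nc5ccc(C#N)cc5)CC4)cc3)nc2n1C1CCCC1` is the next step from compound 1: cyano in place of bromo on an aromatic carbon. Among the measured compounds shown here, no measured step tests this exact swap; the two steps from compound 1 that exist replaced the whole 4-bromophenyl ring by 3-methylphenyl or 3-methoxyphenyl, and each raised the number strongly. Since every change away from 4-bromophenyl seen so far went upward, a moderate rise is expected for compound 4, a number 26.6 percentage points higher from compound 1 to compound 4 (beyond the scatter), though with wide uncertainty. Compound 4 is therefore estimated at 20%, in a range from -10% to 55%.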

Compound 4, percent growth inhibition at one concentration: 86.1%
The estimate for compound 4 lay 66.1 percentage points below the measured number, and the stated range ends below it.
By their numbers in this assay, from the lowest: compound 1; then compound 2; then compounds 3 and 4 (each within the scatter of the next).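

In this assay the ring position that holds bromo proves highly sensitive to a single small exchange: cyano in place of bromo gives a number 92.7 percentage points higher from compound 1 to compound 4 (beyond the scatter) and shows that a 4-substituted phenyl ring is not poor in itself. The 4-cyanophenyl group also gives a number 50.9 percentage points higher from compound 2 to compound 4 (beyond the scatter) and a number 8.9 percentage points higher from compound 3 to compound 4 (within the scatter) so it stands level with 3-methoxyphenyl but clear of 3-methylphenyl. No measurement here explains the size of this change.

Going by these compounds, whether an amine or a carboxylic acid at this ring position would behave like cyano or like bromo remains open. So does whether cyano would give a similar number on another carbon of the ring.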